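A few compounds are considered here, and "the series" means these few. Any claim that something is new, unique, unknown or untested is made for them only; others in the source may bear on it.

Compound 1 `CC(=O)c1cc2cc(C)ccc2oc1=O` and compound 2 `Cc1ccc2oc(=O)c(C(=O)c3ccccc3)cc2c1` share a core with a methyl group on the aromatic ring. In an in vitro assay on BTI-TN-5B1-4 cells for inhibition of Amine oxidase [flavin-containing] B (Homo sapiens), read by fluorescence, with a stated time of 15 min, tested at 100 uM (on this read-out lower numbers stand for less inhibition and higher numbers for more inhibition at the one concentration tested (going by the name of the read-out)), compound 1 gives 40%, and compound 2 gives 40%; the step of no change at the digits printed from compound 1 to compound 2 (within the scatter) shows that the phenyl in place of methyl on a carbonyl carbon made no difference beyond the scatter. Compound 3 `O=C(c1ccccc1)c1cc2cc(Cl)ccc2oc1=O` carries chloro instead of methyl, and in this assay compound 3 is reported as "not active" (no number reported), with no single number given. Compound 4 `O=C(c1ccccc1)c1cc2cc(Br)ccc2oc1=O` differs from compound 3 only by bromo in place of chloro on an aromatic carbon. Within the data shown here, no measured step bears directly on a halogen exchange at this position, so the expectation for compound 4 rests on compound 3 alone. Compound 4 is therefore expected to give 10% in this assay, with a likely range from 0% to 30%.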

Compound 4, a percentage reported as inhibition, at one concentration (the size of the read-out at that concentration, not a potency): "not active" (no number reported)
No number was reported for compound 4; the estimate stays without a comparison.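

Compound 3 and compound 4 both lack a reported number, so no step can be read between them. No measurement shown bears on this result. The compounds shown leave open whether bromo and chloro differ at this position.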